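This account rests on a few compounds, and the source may have more. Where it says the series, first, only, none or still open, it means among the compounds named here.

Among the three measured compounds, compound 2 `C#CCOc1cccc(/C=C/C(=O)Nc2cc(C(=O)c3cc(OC)c(OC)c(OC)c3)ccc2OC)c1` gives the highest number in a functional assay on HeLa cells (Homo sapiens) for cytotoxicity, read by MTT assay, with a stated time of 72 h (a higher number here means a weaker inhibitor, a lower number a stronger inhibitor), at 14000 nM. Compound 1 `COc1cccc(/C=C/C(=O)Nc2cc(OC)c(OC)c(OC)c2)c1` sits close by: in this assay compound 1 gives 12300 nM, and the gap between the two lies within the usual scatter, so nothing separates them. Compound 3 `COc1ccc(C(=O)c2cc(OC)c(OC)c(OC)c2)cc1NC(=O)/C=C/c1ccc(C(F)(F)F)cc1` stands far off: in this assay compound 3 gives 90 nM, and the step of a 160-fold lower number from compound 2 to compound 3 (2.19 log units; beyond the scatter) is the only one measured that bears on the change considered here.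

Compound 4 `COc1ccc(C(=O)c2cc(OC)c(OC)c(OC)c2)cc1NC(=O)/C=C/c1cccc(OC(F)(F)F)c1` arises from compound 2 by a single exchange: trifluoromethyl in place of propargyl on an oxygen on an aromatic ring. Cut one bond further out, the change reads propargyloxy to trifluoromethoxy. The step from compound 2 to compound 3 is related but not the same: there the propargyloxy group left as well and a trifluoromethyl entered, yet as 4-(trifluoromethyl)phenyl, with the oxygen gone. A lower number is therefore expected for compound 4 as well, though with the oxygen kept, the size is uncertain and a more modest step seems the safer guess. The expected step for compound 4 is a 9.3-fold lower number from compound 2 to compound 4 (0.97 log units; beyond the scatter). Compound 4 is estimated at 1500 nM, with a range from 300 nM to 7000 nM.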

Compound 4, half-maximal inhibitory concentration: 7900 nM
The estimate for compound 4 lay 5.3-fold (0.72 log units) below the measured number, and the stated range ends below it.
By their numbers in this assay, from the lowest: compound 3; then compounds 4, 1 and 2 (each within the scatter of the next).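

In this assay, putting trifluoromethyl in place of propargyl on the oxygen gives a 1.8-fold lower number from compound 2 to compound 4 (0.25 log units; within the scatter) and stays within the scatter, so the propargyloxy and trifluoromethoxy groups cannot be told apart on this 3-substituted phenyl, even though their atoms differ. Carrying three fluorines on one carbon is therefore not enough to reach the low number of compound 3, since the step between the two fluorinated compounds is large and beyond the scatter, at an 88-fold higher number from compound 3 to compound 4 (1.94 log units; beyond the scatter) for 3-(trifluoromethoxy)phenyl in place of 4-(trifluoromethyl)phenyl. Nothing measured here accounts for either result.

That large step alters two things at once, the oxygen and the number in the group's name, and the compounds shown contain neither 3-(trifluoromethyl)phenyl nor 4-(trifluoromethoxy)phenyl, so they cannot say which of the two matters. Also open, on these data alone, is how this assay would respond to an amine or a carboxylic acid on this phenyl ring, as only neutral ether and trifluoromethyl groups appear in this comparison.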